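Cyclopropylamino in place of pyrrolidinyl on the shared core

The compounds below may be only part of what the source reports. "The series", "measured", "known", "first", "only" and "open" are said of these compounds alone.

For the measured compounds named here, compound 2 `Cc1cc(Cl)ccc1NC(=O)Nc1nc(Sc2c[nH]c3ccccc23)cc(N2CCCC2)n1` gives 12900 nM in a functional assay on PC-3 cells (Homo sapiens) for inhibition, with a stated time of 72 h (a higher number here means a weaker inhibitor, a lower number a stronger inhibitor), the lower of the two numbers known so far; its only neighbour, compound 1 `Cc1cc(Cl)ccc1NC(=O)Nc1nc(Nc2ccccc2)cc(Sc2c[nH]c3ccccc23)n1`, gives 41900 nM in this assay. Going by the values given here, the single measured step, a 3.2-fold lower number from compound 1 to compound 2 (0.51 log units; beyond the scatter), was modest but beyond the scatter. Compound 3 `Cc1cc(Cl)ccc1NC(=O)Nc1nc(NC2CC2)cc(Sc2c[nH]c3ccccc23)n1` differs from compound 2 by cyclopropylamino in place of pyrrolidin-1-yl on an aromatic carbon. Among the compounds with values here, no measured step matches this change; the step of a 3.2-fold lower number from compound 1 to compound 2 (0.51 log units; beyond the scatter) bears on it only loosely, since it exchanged anilino for pyrrolidin-1-yl and lowered the number. Replacing pyrrolidin-1-yl in turn with cyclopropylamino, a smaller group than anilino, is expected to move the number back upward by a small step, a 1.6-fold higher number from compound 2 to compound 3 (0.19 log units; within the scatter), likely within the scatter or just beyond it. Compound 3 is therefore estimated at about 20000 nM in this assay, with a range from 8000 nM to 50000 nM.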

Compound 3, half-maximal inhibitory concentration: 11100 nM
Beside the measured number, compound 3's estimate is 1.8-fold (0.26 log units) above it; the measured number falls inside the stated range.
By their numbers in this assay, from the lowest: compounds 3 and 2 (each within the scatter of the next); then compound 1.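

In this assay, cyclopropylamino in place of pyrrolidin-1-yl gives a 1.2-fold lower number from compound 2 to compound 3 (0.07 log units; within the scatter), so this change does not separate the two groups at this position, although cyclopropylamino carries a hydrogen-bond donor and pyrrolidin-1-yl carries none. Cyclopropyl in place of phenyl on the nitrogen gives a 3.8-fold lower number from compound 1 to compound 3 (0.58 log units; beyond the scatter), and together with a 3.2-fold lower number from compound 1 to compound 2 (0.51 log units; beyond the scatter) this sets compound 1, the anilino compound, apart from the other two. No measured evidence accounts for either result.

The compounds shown leave open whether a morpholine ring, a piperazine ring or a longer alkylamine chain at this position would shift the number in this cell assay. They also leave open whether any replacement here could bring the number well below that of compound 2 and compound 3.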